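A few compounds are considered here, and "the series" means these few. Any claim that something is new, unique, unknown or untested is made for them only; others in the source may bear on it.

Compound 1 `O=C(/C=C\c1ccccc1)N1N=C(c2ccncc2)OC1c1c[nH]c2ccccc12` is the reference point of the series. In an ADME assay on A549 cells (Homo sapiens) for cytotoxicity, read by MTT assay, with a stated time of 48 h (a higher number here means a weaker inhibitor of growth, a lower number a stronger inhibitor of growth), compound 1 gives only a limit of the assay, > 30 ug/mL. Compound 2 `O=C(/C=C\c1ccccc1O)N1N=C(c2ccncc2)OC1c1c[nH]c2ccccc12` carries a hydroxy in place of hydrogen on an aromatic carbon. In this assay compound 2 also gives only a limit, > 30 ug/mL. The step that the two limits leave unreadable from compound 1 to compound 2 therefore stays unreadable, both values sitting at the limit of > 30 ug/mL in this assay, at which 2 of the 2 values shown sit. Compound 3 `O=C(/C=C\c1cccc(O)c1)N1N=C(c2ccncc2)OC1c1c[nH]c2ccccc12` differs from compound 1 by hydroxy in place of hydrogen on an aromatic carbon. Among the compounds with values here, the only related measured step is a step that the two limits leave unreadable from compound 1 to compound 2, which gives no readable size, so no step beyond the scatter is expected here. For compound 3 in this assay the expected value is 45 ug/mL, within 20 ug/mL to 120 ug/mL, most likely again reported only as a limit. The expected step that the limit leaves unreadable from compound 1 to compound 3 is accordingly none beyond the scatter.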

Compound 3, concentration for 50% growth inhibition: > 30 ug/mL
Compound 3: a limit, no number; the forecaster's own chance of this, stated with the estimate: 80%; the middle value lies beyond the limit too.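

No new step can be read among compound 1, compound 2 and compound 3 in this assay, as each value is a limit, not a number: the limit of > 30 ug/mL in this assay, at which 3 of the 3 values shown sit. Going by these compounds, whether hydroxy in place of hydrogen on an aromatic carbon changes growth inhibition at all remains open.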